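This account rests on a few compounds, and the source may have more. Where it says the series, first, only, none or still open, it means among the compounds named here.

Measured so far in an assay for displacement of a labelled ligand from melanin-concentrating hormone receptor 1 (Homo sapiens), read by fluorescence; on this read-out higher numbers stand for weaker inhibition and lower numbers for stronger inhibition:
compound 1, `CC(=O)Nc1cccc(C2CCN(CCCn3c(-c4ccccc4)nc4ccccc43)CC2)c1`, gives 2 nM;
compound 2, `CC(=O)Nc1cccc(C2CCN(CCCn3c(-c4ccc(F)cc4)nc4ccccc43)CC2)c1`, gives 56 nM.

Within the data shown here, compound 2 holds the higher of the two numbers in this assay; its only neighbour is compound 1, and the step of a 28-fold higher number from compound 1 to compound 2 (1.45 log units; beyond the scatter) separates them. Compound 3, `CC(=O)Nc1cccc(C2CCN(CCCn3c(-c4ccc(Cl)cc4Cl)nc4ccccc43)CC2)c1`, is not yet measured. It differs from compound 2 by 2,4-dichlorophenyl in place of 4-fluorophenyl on an aromatic carbon. Among the measured compounds shown here, the one measured step that bears on this change is a 28-fold higher number from compound 1 to compound 2 (1.45 log units; beyond the scatter), which placed a single halogen on the ring that now becomes 2,4-dichlorophenyl and was large. For the measured compounds named here, the new change keeps a halogen on that ring and adds another; no measured pair shows what a second or a heavier halogen does there, so the direction rests on that single step alone. For compound 3 a further but smaller rise of the number is estimated, a 2.1-fold higher number from compound 2 to compound 3 (0.33 log units; beyond the scatter). Compound 3 is expected to give 120 nM in this assay, within 25 nM to 600 nM.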

Compound 3, half-maximal inhibitory concentration: 3 nM
Estimate against measurement, compound 3: 40-fold (1.60 log units) above; measured number outside the range, below it.
By their numbers in this assay, from the lowest: compounds 1 and 3 (each within the scatter of the next); then compound 2.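

In this assay, a halogen on this phenyl ring does not by itself bring the loss seen with 4-fluorophenyl: there is a 19-fold lower number from compound 2 to compound 3 (1.27 log units; beyond the scatter) (large), and 2,4-dichlorophenyl stands level with the plain phenyl ring (the step is a 1.5-fold higher number from compound 1 to compound 3 (0.18 log units; within the scatter)). The earlier step (a 28-fold higher number from compound 1 to compound 2 (1.45 log units; beyond the scatter)) therefore belongs, within these compounds, to 4-fluorophenyl and not to halogen as such, and the aromatic carbon between two ring nitrogen atoms accepts 2,4-dichlorophenyl with no change beyond the scatter from phenyl. Nothing available explains the gap between the two halogenated rings.

From the compounds shown here alone, whether that gap follows from chlorine in place of fluorine or from the second halogen stays open; a monochlorophenyl or a difluorophenyl group would separate the two. Also open, going by these compounds, is how a methoxy group or a pyridine ring would fare at this position.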